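Pyridyl replacement on the oxadiazole: from compound 3 to compound 4

The source may hold more compounds than are shown below. What is called first, only, known or untested is meant among the compounds shown, and "the series" means these compounds.

Compound 3 `C[C@H](NC(=O)c1cc(C(F)(F)F)nn1C)c1nc(-c2cccnc2)no1` is the weakest of the three measured compounds in an assay on T-REx-293 cells for inhibition of potassium channel subfamily T member 1 (Homo sapiens), read by patch clamp (on this read-out lower numbers stand for stronger inhibition and higher numbers for weaker inhibition), giving 11800 nM. Its nearest neighbour, compound 2 `Cc1cccc(-c2nc(C(C)NC(=O)c3cc(C(F)(F)F)nn3C)no2)c1`, gives 977 nM, and compound 1 `CCc1cc(C(=O)N[C@@H](C)c2nc(-c3cccc(C)c3)no2)n(C)n1` gives 335 nM; both gaps to compound 3 lie beyond the scatter. Compound 4 `CO[C@H](C)c1cc(-c2noc([C@H](C)NC(=O)c3cc(C(F)(F)F)nn3C)n2)ccn1` differs from compound 3 in one place: a group of 10 heavy atoms (8 carbon, 1 nitrogen, 1 oxygen; one six-membered aromatic ring with 1 hetero atom) in place of a group of 6 heavy atoms (5 carbon, 1 nitrogen; one six-membered aromatic ring with 1 hetero atom), on an aromatic carbon. Here the pyridin-3-yl leaves and a larger ring carrying a defined stereocentre enters on the aromatic carbon between two ring nitrogen atoms. Within the data shown here, no measured pair shows this change, so the step in this assay is uncertain; a moderate move towards a lower number is expected, because compound 3 at 11800 nM sits far from compound 2. Compound 4 is estimated at 3500 nM (range 800 nM to 15000 nM), which would mean a 3.4-fold lower number from compound 3 to compound 4 (0.53 log units; beyond the scatter).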

Compound 4, half-maximal inhibitory concentration: 778 nM
Estimate against measurement, compound 4: 4.5-fold (0.65 log units) above, and the stated range ends above it.
By their numbers in this assay, from the lowest: compound 1; then compounds 4 and 2 (each within the scatter of the next); then compound 3.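

In this assay, the aromatic carbon between two ring nitrogen atoms responds strongly to the group it carries: replacing pyridin-3-yl with the larger ring bearing a defined stereocentre gives a 15-fold lower number from compound 3 to compound 4 (1.18 log units; beyond the scatter). Among these compounds, this is the first single-place step, and it shows that this position accepts the larger group with a large gain. Nothing measured here accounts for the step. On these data alone, it remains open whether the gain comes from the side chain or from its stereocentre. As far as these compounds go, how an amine or a carboxylic acid there would read also remains unknown.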